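Chloro for fluoro and clearance in a quinoline sulfone series

The compounds below may be only part of what the source reports. "The series", "measured", "known", "first", "only" and "open" are said of these compounds alone.

Of the compounds shown here, three of one shared core have been measured in an ADME assay on microsomes from liver (Homo sapiens) for metabolic stability, tested at 2.5 uM; on this read-out lower numbers stand for slow clearance and higher numbers for fast clearance. Compound 1 `O=S(=O)(c1ccc(F)c(Cl)c1)c1cnc2cc(F)ccc2c1-c1ccc(Cl)cc1` gives 0.39 mL/min. Compound 2 `O=S(=O)(c1ccc(F)c(F)c1)c1cnc2cc(F)ccc2c1-c1ccc(Cl)cc1` gives 0.01 mL/min. Compound 3 `O=S(=O)(c1ccc(F)c(Cl)c1)c1cnc2c(F)cccc2c1-c1ccc(F)cc1` gives 0.19 mL/min. Compound 2 and compound 1 differ by one change, (chloro in place of fluoro on an aromatic carbon), which made a 39-fold higher number from compound 2 to compound 1 (1.59 log units; beyond the scatter). The cores of compound 3 and compound 2 differ in a way that is not broken down here. Compound 4 `O=S(=O)(c1ccc(F)c(Cl)c1)c1cnc2c(F)cccc2c1-c1ccc(Cl)cc1`, not yet measured, carries the same kind of change relative to compound 3, (chloro in place of fluoro on an aromatic carbon); here the chloro sits para to a large group rather than ortho to a fluoro group and meta to a large group. Among the compounds with values here, a smaller rise is expected, a 2.6-fold higher number from compound 3 to compound 4 (0.42 log units; beyond the scatter), because the only step of this kind seen is a 39-fold higher number from compound 2 to compound 1 (1.59 log units; beyond the scatter) at a different place. Compound 4 is thus estimated at 0.5 mL/min.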

Compound 4, intrinsic clearance in a liver preparation (reported as CLH), per the amount of preparation that the assay uses: 0.01 mL/min
Compound 4: the middle estimate sits 50-fold (1.70 log units) above what was measured, outside the stated range (below it).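

In this assay, chloro in place of fluoro now gives a clear fall, a 19-fold lower number from compound 3 to compound 4 (1.28 log units; beyond the scatter), whereas the earlier step went up. A result for this change on one core therefore cannot simply be carried over to another core in this series, in size or in direction: the same change on two cores in this assay, a 39-fold higher number (1.59 log units; beyond the scatter) from compound 2 to compound 1 and a 19-fold lower number (1.28 log units; beyond the scatter) from compound 3 to compound 4, 740-fold (2.87 log units) apart, beyond the scatter of two such steps

Within the data shown here, with only two steps, made at different places on different cores, the data cannot separate the role of the place from that of the core, and they give no reason for the reversal.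

The compounds shown leave open how a bromo or methoxy group would read at this place. They also leave open whether 4-fluorophenyl to 4-chlorophenyl would lower the number on a further core.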